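From nitro to carboxy: estimating compound 4

The source may hold more compounds than are shown below. What is called first, only, known or untested is meant among the compounds shown, and "the series" means these compounds.

- compound 1 `NS(=O)(=O)c1ccc(S(=O)(=O)CCCO)cc1`: 7200 ug/mL
- compound 2 `NS(=O)(=O)c1ccc(S(=O)(=O)CCCO)c(F)c1`: 6600 ug/mL
- compound 3 `NS(=O)(=O)c1ccc(S(=O)(=O)CCCO)c([N+](=O)[O-])c1`: 800 ug/mL
- compound 4 `NS(=O)(=O)c1ccc(S(=O)(=O)CCCO)c(C(=O)O)c1`: not yet measured

In a physicochemical assay for solubility, at pH 7.4 (on this read-out higher numbers stand for higher solubility and lower numbers for lower solubility), compound 3 stands lowest of the three, at 800 ug/mL. The next change swaps a single group on the shared core to give compound 4: carboxy in place of nitro on an aromatic carbon.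

Going by the values given here, no measured compound carries carboxy, so nothing here tests that group directly. The closest evidence is what happened when nitro entered. Nitro in place of hydrogen gave a 9.0-fold lower number from compound 1 to compound 3 (0.95 log units; beyond the scatter), and nitro in place of fluoro gave an 8.3-fold lower number from compound 2 to compound 3 (0.92 log units; beyond the scatter). Both steps are modest. Fluoro in place of hydrogen, by contrast, gave a 1.1-fold lower number from compound 1 to compound 2 (0.04 log units; within the scatter). Only compound 3 carries nitro, so this is a thin basis, and the reasoning assumes that compound 4 lands near the two compounds without nitro. On that assumption, a rise of similar size to the nitro steps is expected in this assay, and the estimated step is a 7.5-fold higher number from compound 3 to compound 4 (0.88 log units; beyond the scatter). For compound 4 the expected value is 6000 ug/mL. For compound 4 the estimated range runs from 1500 ug/mL to 24000 ug/mL.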

Compound 4, solubility: 53000 ug/mL
Estimate against measurement, compound 4: 8.8-fold (0.95 log units) below, outside the stated range (above it).
By their numbers in this assay, from the lowest: compound 3; then compounds 2 and 1 (each within the scatter of the next); then compound 4.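

In this assay, going by these compounds alone, this aromatic carbon can push the number up as well as down: carboxy in place of hydrogen gives a 7.4-fold higher number from compound 1 to compound 4 (0.87 log units; beyond the scatter) and carboxy in place of fluoro gives an 8.0-fold higher number from compound 2 to compound 4 (0.90 log units; beyond the scatter) and so sets compound 4 apart, whereas the earlier compounds showed only a fall with nitro and no step beyond the scatter with fluoro. Nitro and carboxy have the same count of heavy atoms and sit on the same carbon, yet exchanging them gives a 66-fold higher number from compound 3 to compound 4 (1.82 log units; beyond the scatter) as the largest step in the series, so at this position the heavy-atom count alone does not settle the number, and the two groups differ in their counts of hydrogen-bond donors and acceptors. Nothing measured here tells what lies behind this rise.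

The compounds shown leave open whether the rise belongs to carboxy itself or would also come with another group on this aromatic carbon, such as an amide or an amine. They also leave open whether carboxy would give a step of similar size at another place on the shared core, or on a longer chain.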